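The source may report more compounds than this note shows. Statements on the series, on what has been measured and on what is new or still open speak of the compounds shown alone.

Measured so far in a functional assay on A673 cells (Homo sapiens) for cytotoxicity, read by fluorescence and resazurin assay, with a stated time of 72 h; a higher number here means a weaker inhibitor, a lower number a stronger inhibitor:
- Compound 1 `Nc1nc(Nc2ccc(S(N)(=O)=O)cc2)sc1C(=O)c1ccccc1[N+](=O)[O-]`: 270 nM
- Compound 2 `Nc1nc(Nc2ccc(S(N)(=O)=O)cc2)sc1C(=O)c1cccc(F)c1`: 450 nM

Among the compounds with values here, compound 2 gives 450 nM in this assay, and that value cannot be told apart from the one for compound 1. The next compound to consider is compound 3 `Nc1cccc(C(=O)c2sc(Nc3ccc(S(N)(=O)=O)cc3)nc2N)c1`. It keeps the whole of compound 2 except for one group, with amino in place of fluoro on an aromatic carbon, meta to a large group: amino in place of fluoro on an aromatic carbon. The 3-fluorophenyl thus becomes 3-aminophenyl.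

Within the data shown here, only one measured step bears on this change. Compounds 1 and 2 differ in the group on the carbonyl carbon, with 3-fluorophenyl in place of 2-nitrophenyl, and that swap gave a 1.7-fold higher number from compound 1 to compound 2 (0.22 log units; within the scatter). This is thin evidence, since amino itself has not yet been measured on this core. Among the measured compounds shown here, still, the one exchange seen so far at this part of the molecule left the number within the scatter, so no step beyond the scatter is expected here, and the direction stays open. The expected change is a 1.2-fold lower number from compound 2 to compound 3 (0.07 log units; within the scatter). For compound 3 the estimated value is 380 nM, with an expected range of 130 nM to 1100 nM.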

Compound 3, half-maximal inhibitory concentration: 8800 nM
The estimate for compound 3 lay 23-fold (1.36 log units) below the measured number; measured number outside the range, above it.
By their numbers in this assay, from the lowest: compounds 1 and 2 (each within the scatter of the next); then compound 3.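

In this assay, the group on the carbonyl carbon turns out to matter a great deal: amino in place of fluoro, on an aromatic carbon meta to a large group, gives a 20-fold higher number from compound 2 to compound 3 (1.29 log units; beyond the scatter) even though one heavy atom simply replaces another. Compared with compound 1, the 3-aminophenyl group gives a 33-fold higher number from compound 1 to compound 3 (1.51 log units; beyond the scatter) as well, whereas the only earlier exchange at this part of the molecule stayed within the scatter, so compound 1 and compound 2 alone gave no hint that this part could be so sensitive. Amino brings a hydrogen-bond donor and a hydrogen-bond acceptor that fluoro lacks, but no measurement at hand explains the large step.

Going by these compounds, it remains open whether the large step belongs to the free amino group alone or would persist with an acetamide or a dimethylamino group in its place. On these data alone, it is also open whether a hydroxyl or a methoxy group on the same aromatic carbon would give a number close to that of compound 2 or close to that of compound 3.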